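The compounds below may be only part of what the source reports. "The series", "measured", "known", "first", "only" and "open" are said of these compounds alone.

Measured compounds in a functional assay on T47D cells (Homo sapiens) for cytotoxicity, read by sulforhodamine B assay, with a stated time of 48 h, tested at 0.01 uM; on this read-out lower numbers stand for a stronger effect and higher numbers for a weaker effect at the one concentration tested:
- compound 1 `COc1cc(-c2cc(/C=C/C(=O)c3ccc(Cl)c(Cl)c3)[nH]n2)cc(OC)c1OC` gives 90%
- compound 2 `COc1ccc(-c2cc(/C=C/C(=O)c3cc(OC)c(OC)c(OC)c3)[nH]n2)cc1OC` gives 91%
- compound 3 `COc1ccc(-c2cc(/C=C/C(=O)c3ccc(N)cc3)[nH]n2)cc1` gives 98%

All three values sit close together at the single concentration tested, and none of the three is separated from another by more than the scatter of this assay. Compound 2 holds the second highest of the three numbers; its nearest neighbour is compound 1, with a value a shade lower and within the scatter, and its furthest is compound 3, with a value somewhat higher yet still within the scatter. On these numbers, then, no ordering among compounds 1, 2 and 3 can be defended.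

The step to the unmeasured compound 4 `COc1cc(C(=O)/C=C/c2cc(-c3cc(OC)c(OC)c(OC)c3)n[nH]2)cc(OC)c1OC` is a single change: methoxy in place of hydrogen on an aromatic carbon

Going by the values given here, no step between measured compounds is on record for this change, so there is no measured precedent to lean on. Given that compounds 1, 2 and 3 all read alike, the expected step from compound 2 to compound 4 is no change at the digits printed from compound 2 to compound 4 (within the scatter), that is, no shift beyond the scatter in either direction. Compound 4 is therefore expected to give about 91% in this assay, with a likely range from 80% to 100%.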

Compound 4, a percentage reported as activity, at one concentration (the size of the read-out at that concentration, not a potency): 91%
Compound 4: middle estimate and measured number agree at the digits printed; the range from low to high includes it.
By their numbers in this assay, from the lowest: compounds 1, 2, 4 and 3 (each within the scatter of the next).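

Going by these compounds alone, with methoxy in place of hydrogen on an aromatic carbon, ortho to a methoxy group and meta to a large group, this assay shows no change at the digits printed from compound 2 to compound 4 (within the scatter) as the first comparison between compounds that differ in one place. At the one concentration tested, this position therefore accepts the added methoxy without a shift beyond the scatter, something compounds 1, 2 and 3 could not show, as they differ from one another in more than one place. Nothing on hand bears on the reason for this reading.

On these data alone, whether a hydroxyl, an amine or a chlorine on this same aromatic carbon would read alike remains open. Also open, as far as these compounds go, is whether the step stays within the scatter at a higher concentration, where the compounds might separate.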